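Bromo Series: Phenyl in Place of Dichlorophenyl

The source may report more compounds than this note shows. Statements on the series, on what has been measured and on what is new or still open speak of the compounds shown alone.

Among the compounds with values here, compound 2 `Clc1ccc(Cc2nn3c(Br)c(-c4ccc(Cl)cc4Cl)nc3s2)cc1` is the only compound that returns a number in an ADME assay on CCRF-CEM cells (Homo sapiens) for cytotoxicity, with a stated time of 72 h; a lower number here means a stronger inhibitor, a higher number a weaker inhibitor; here compound 2 gives 106000 nM. The other value shown is not a number but a limit of this assay, marked (the limit of > 250000 nM in this assay, at which 1 of the 2 values shown sits). Compound 1 `Clc1ccc(Cc2nn3cc(-c4ccccc4)nc3s2)cc1` shares the core but lacks the bromo group and carries phenyl in place of the dichlorophenyl. In this assay compound 1 reaches only the limit of > 250000 nM. Compound 3 `Clc1ccc(Cc2nn3c(Br)c(-c4ccccc4)nc3s2)cc1` has not yet been measured in this assay. Compound 3 differs from compound 2 by phenyl in place of 2,4-dichlorophenyl on an aromatic carbon. Within the data shown here, no step between two measured compounds is available, so the size of this step is not known from a direct pair. For compound 3 a step toward weaker inhibition, larger than the usual scatter, is expected, a 1.9-fold higher number from compound 2 to compound 3 (0.28 log units; within the scatter). Compound 3 is expected to give about 200000 nM in this assay, with a range from 80000 nM to 500000 nM, and there is a fair chance that this assay reports only a limit rather than a number.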

Compound 3, half-maximal inhibitory concentration: > 250000 nM
Compound 3 gave a limit, no number; the forecaster's own chance of this, stated with the estimate: 45%; middle value at least 1.2-fold (0.09 log units) from the limit.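

With the bromo group held in place, this position now has its first direct comparison in this assay: phenyl in place of 2,4-dichlorophenyl on this aromatic carbon gives an at least 2.3-fold higher number from compound 2 to compound 3 (0.37 log units; beyond the scatter). This step lies beyond the usual scatter, but it sets only a lower bound on the change, as compound 3 returns a limit and not a number. The step for bromo in place of hydrogen, from compound 1 to compound 3, cannot be read, so only the compound carrying 2,4-dichlorophenyl gives a number, and the two phenyl compounds cannot be told apart: the limit of > 250000 nM in this assay, at which 2 of the 3 values shown sit.

The compounds shown leave open how much of the step belongs to each of the two chlorine atoms, and whether a phenyl carrying a single chlorine, a methoxy group or an amine on this aromatic carbon would return a number in this assay. Within the data shown here, they also leave open what the bromo group contributes when 2,4-dichlorophenyl is kept, as no compound pairs hydrogen with that group.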